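Shifting the naphthyl attachment point in compound 4

The compounds below may be only part of what the source reports. "The series", "measured", "known", "first", "only" and "open" are said of these compounds alone.

Compound 3, `c1ccc(-c2cc(N(CCCN3CCCCC3)Cc3cccc4ccccc34)on2)cc1`, gives 500 nM in a functional assay for antagonist activity at proteinase-activated receptor 1 (Homo sapiens) (a higher number here means a weaker inhibitor, a lower number a stronger inhibitor), the lowest of the three numbers at hand. Compound 1, `c1ccc(CN(CCCN2CCCCC2)c2cc(-c3ccccc3)no2)cc1`, gives 9000 nM, and compound 2, `Clc1cccc(CN(CCCN2CCCCC2)c2cc(-c3ccccc3)no2)c1`, gives 1000 nM. The steps of an 18-fold lower number from compound 1 to compound 3 (1.26 log units; beyond the scatter) and a 2.0-fold lower number from compound 2 to compound 3 (0.30 log units; within the scatter) show what replacing the benzyl group brought. Compound 4, `c1ccc(-c2cc(N(CCCN3CCCCC3)Cc3ccc4ccccc4c3)on2)cc1`, differs from compound 3 only in naphthalen-2-yl in place of naphthalen-1-yl on a saturated chain carbon bound to a nitrogen on an aromatic ring. For the measured compounds named here, no measured step swaps one naphthyl for the other, so the change is untested here; both groups keep the same atoms, and the earlier steps concern different groups. Compound 4 is therefore expected to give 700 nM in this assay, in the range 250 nM to 2000 nM. The expected step of a 1.4-fold higher number from compound 3 to compound 4 (0.15 log units; within the scatter) lies within the scatter.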

Compound 4, half-maximal inhibitory concentration: 2000 nM
Estimate against measurement, compound 4: 2.9-fold (0.46 log units) below; measured number inside the range.
By their numbers in this assay, from the lowest: compounds 3, 2 and 4 (each within the scatter of the next, the first and the last beyond it); then compound 1.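

Even though no atom changes, where the naphthyl group is attached matters in this assay (a 4.0-fold higher number from compound 3 to compound 4 (0.60 log units; beyond the scatter)). Naphthalen-2-yl still improves on the plain phenyl (a 4.5-fold lower number from compound 1 to compound 4 (0.65 log units; beyond the scatter)), yet it cannot be separated from 3-chlorophenyl (a 2.0-fold higher number from compound 2 to compound 4 (0.30 log units; within the scatter)). Nothing available explains why the two attachment points differ. Still open, going by these compounds, is whether a methoxy group on the naphthalen-1-yl group would keep or extend its advantage. It is also unknown how a quinolinyl group, with a ring nitrogen, would compare at this position.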